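From piperidin-1-yl to 2-aminoethyl on compound 3

The source may report more compounds than this note shows. Statements on the series, on what has been measured and on what is new or still open speak of the compounds shown alone.

Measured so far in a functional assay on PC-3 cells (Homo sapiens) for cytotoxicity, read by MTT assay, with stated times of 48 h and 4 h; a lower number here means a stronger inhibitor, a higher number a weaker inhibitor:

- Compound 1 `COc1ccc(/C=C/c2nc(NCCCCN)c3ccccc3n2)cc1OC` gives > 100000 nM as a limit
- Compound 2 `COc1ccc(/C=C/c2nc(NCCN(C(C)C)C(C)C)c3cc(Cl)ccc3n2)cc1OC` gives > 100000 nM as a limit
- Compound 3 `COc1ccc(/C=C/c2nc(NCCN3CCCCC3)c3cc(Cl)ccc3n2)cc1OC` gives 21200 nM

Only compound 3 has a true number. Compound 1 and compound 2 stand at the limit of > 100000 nM in this assay, at which 2 of the 3 values shown sit.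

Compound 4 `COc1ccc(/C=C/c2nc(NCCCCN)c3cc(Cl)ccc3n2)cc1OC` differs from compound 3 in one place: 2-aminoethyl in place of piperidin-1-yl on a saturated chain carbon, two bonds along the chain from a nitrogen on an aromatic ring. There, 2-(piperidin-1-yl)ethyl gives way to 4-aminobutyl.

Within the data shown here, one measured step bears on this place, an at least 4.7-fold lower number from compound 2 to compound 3 (0.67 log units; beyond the scatter), and it shows that the group there can move the number in this assay. Compound 1 carries the same (4-aminobutyl)amino group and sits at the limit of > 100000 nM. A step of similar size towards a higher number, meaning a weaker inhibitor, is therefore expected, and the result may be reported only as a limit. The expected change is a 2.8-fold higher number from compound 3 to compound 4 (0.45 log units; beyond the scatter). Compound 4 is estimated at 60000 nM, with an expected range of 20000 nM to 150000 nM.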

Compound 4, half-maximal inhibitory concentration: > 100000 nM
Compound 4 gave a limit, no number; the forecaster's own chance of this, stated with the estimate: 50%; middle value at least 1.6-fold (0.22 log units) away from the limit.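

In this assay, 2-aminoethyl in place of piperidin-1-yl gives an at least 4.7-fold higher number from compound 3 to compound 4 (0.67 log units; beyond the scatter), so of the compounds shown that carry chloro, only compound 3 with its piperidin-1-yl group reaches a true number. Compound 4 stands at a limit of the assay, which means this step gives only the smallest size of the change, and the steps to compound 4 from compound 2 and from compound 1 cannot be read, so nothing can be said about chloro in place of hydrogen on the (4-aminobutyl)amino compounds. Most of the series now rests on one ceiling: the limit of > 100000 nM in this assay, at which 3 of the 4 values shown sit.

As far as these compounds go, whether a pyrrolidin-1-yl or morpholin-4-yl group at this place would also give a true number remains open. So does what hydrogen in place of chloro would do on compound 3.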